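This account rests on a few compounds, and the source may have more. Where it says the series, first, only, none or still open, it means among the compounds named here.

Measured in an ADME assay on HepG2 cells (Homo sapiens) for cytotoxicity, read by MTT assay; on this read-out higher numbers stand for weaker inhibition and lower numbers for stronger inhibition:
- compound 1 `O=C(NCc1ccccc1)Oc1ccc(Cl)cc1C(=O)Nc1ccc(F)cc1`: > 125000 nM
- compound 2 `O=C(Nc1ccccc1)Oc1ccc(Cl)cc1C(=O)Nc1ccc(F)cc1`: > 20000 nM
- compound 3 `O=C(NC1CCCCC1)Oc1ccccc1C(=O)Nc1ccccc1`: 49000 nM

Compound 2 stands only at a limit, > 20000 nM. Compound 1 likewise gives only a limit, > 125000 nM. Compound 4 `O=C(NC1CCCCC1)Oc1ccc(Cl)cc1C(=O)Nc1ccc(F)cc1` has cyclohexyl in place of phenyl on an amide-type nitrogen. Among the compounds with values here, the one measured step, a step that the two limits leave unreadable from compound 1 to compound 2, changes the group on that same nitrogen but offers no size to carry over. Within the data shown here, compound 3, which also bears cyclohexyl, gives 49000 nM, the only true number in this assay, so a value near it is expected. That implies an expected step that the limit leaves unreadable from compound 2 to compound 4, toward weaker inhibition if any, and its size remains loose. For compound 4 the estimate is 50000 nM, with an expected range of 20000 nM to 125000 nM.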

Compound 4, half-maximal inhibitory concentration: 21200 nM
Beside the measured number, compound 4's estimate is 2.4-fold (0.37 log units) above it; the measured number falls inside the stated range.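

In this assay, within the data shown here, compound 4 gives the first true number on the core of compound 1, so cyclohexyl on the amide-type nitrogen is the only group there that is not held at a limit. Cyclohexyl in place of benzyl at this nitrogen gives an at least 5.8-fold lower number from compound 1 to compound 4 (0.77 log units; beyond the scatter). The step from phenyl to cyclohexyl cannot be read, because compound 2 stands only at a limit: the limit of > 20000 nM in this assay, at which 1 of the 4 values shown sits.

The compounds shown leave open how a straight n-hexyl chain or a piperidin-4-yl group on that nitrogen would read, and how far compound 2 truly lies from compound 4.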